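The source may report more compounds than this note shows. Statements on the series, on what has been measured and on what is new or still open speak of the compounds shown alone.

Working notes on the series, all values from an ADME assay on microsomes from liver (Mus musculus) for metabolic stability, read by LC-MS, with a stated time of 10 min, tested at 0.5 uM; a higher number here means that more of the compound is left, a lower number that less of the compound is left. Compound 1 (`CC(C)N1CCN(CCCN(C[C@H]2Cc3ccccc3CN2)[C@H]2CCCc3cccnc32)CC1`) gives 58%, compound 2 (`CN1CCN(CCCN(C[C@H]2Cc3ccccc3CN2C)[C@H]2CCCc3cccnc32)CC1`) gives 43%, and compound 3 (`CCN1CCN(CCCN(C[C@H]2Cc3ccccc3CN2)[C@H]2CCCc3cccnc32)CC1`) gives 19%. Compound 3 is the lowest of the three, and both other values lie beyond the scatter from it.

The next structure is compound 4 (`c1ccc2c(c1)CN[C@@H](CN(CCCN1CCN(C3CC3)CC1)[C@H]1CCCc3cccnc31)C2`), which has cyclopropyl in place of ethyl on an amine nitrogen in a ring. Within the data shown here, one measured step bears directly on this change, as it falls on the same amine nitrogen. It is hydrogen in place of methyl on a saturated chain carbon bound to that nitrogen, and it reads a number 39 percentage points lower from compound 1 to compound 3 (beyond the scatter). This large step shows that this assay can respond strongly to the group at this nitrogen. Compound 2 differs from compound 3 in more than one place, so it gives no clean comparison.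

Structurally, cyclopropyl lies nearer to the group on compound 1 than ethyl does, so a rise is expected, though smaller than the full measured step. Among the measured compounds shown here, with only one step as a guide, the uncertainty is wide. The expected step is a number 23 percentage points higher from compound 3 to compound 4 (beyond the scatter). The estimate for compound 4 is 42%, with an expected range from 24% to 62%.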

Compound 4, percent of the compound remaining: 3%
The estimate for compound 4 lay 39 percentage points above the measured number, and the stated range ends above it.
By their numbers in this assay, from the lowest: compound 4; then compound 3; then compound 2; then compound 1.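

In this assay, cyclopropyl in place of ethyl on the amine nitrogen in the ring gives a number 16 percentage points lower from compound 3 to compound 4 (beyond the scatter) in the percent of compound remaining, and cyclopropyl in place of isopropyl on that nitrogen gives a number 55 percentage points lower from compound 1 to compound 4 (beyond the scatter) in the same read-out. This position therefore separates three groups rather than two, with isopropyl highest, ethyl in the middle and cyclopropyl lowest, and both steps are beyond the scatter. The order shows that a cyclopropyl group does not read as an intermediate between ethyl and isopropyl here, and nothing available explains the drop from any measured property of these groups.

Open, from the compounds shown here alone, is how this position would read with a cyclobutyl group, a tert-butyl group or an acetyl group on the same nitrogen, any of which would show whether the low number stays with the three-membered ring or extends to other groups. Also open, going by these compounds, is whether the order of isopropyl, ethyl and cyclopropyl holds when a methyl group sits on the other ring nitrogen of the core, as it does in compound 2.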